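The source may hold more compounds than are shown below. What is called first, only, known or untested is meant among the compounds shown, and "the series" means these compounds.

Compound 2 `COc1ccc(S(=O)(=O)c2cnc3cc(F)ccc3c2-c2ccc(Cl)cc2)cc1` stands highest of the two compounds measured in an ADME assay on microsomes from liver (Homo sapiens) for metabolic stability, tested at 2.5 uM; a lower number here means slower removal, a higher number faster removal of the compound: compound 2 gives 1.28 mL/min, while compound 1 `O=S(=O)(c1ccc(F)c(Cl)c1)c1cnc2cc(F)ccc2c1-c1ccc(Cl)cc1` gives 0.39 mL/min. For the measured compounds named here, the single measured step, a 3.3-fold higher number from compound 1 to compound 2 (0.52 log units; beyond the scatter), is the only guide available. Compound 3 `O=S(=O)(c1ccc(F)c(F)c1)c1cnc2cc(F)ccc2c1-c1ccc(Cl)cc1` differs from compound 2 in one place: 3,4-difluorophenyl in place of 4-methoxyphenyl on a sulfonyl sulfur. The 3,4-difluorophenyl that enters resembles the 3-chloro-4-fluorophenyl of compound 1 far more than it resembles the 4-methoxyphenyl it replaces. Since a 3.3-fold higher number from compound 1 to compound 2 (0.52 log units; beyond the scatter) accompanied the move from 3-chloro-4-fluorophenyl to 4-methoxyphenyl, a move back toward a halogen-bearing group is expected to bring the number down again, although whether a second fluorine matches a chlorine exactly is not shown by these data. Compound 3 is therefore expected to give about 0.5 mL/min in this assay, within 0.25 mL/min to 1 mL/min. That amounts to an expected step of a 2.6-fold lower number from compound 2 to compound 3 (0.41 log units; beyond the scatter).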

Compound 3, intrinsic clearance in a liver preparation (reported as CLH), per the amount of preparation that the assay uses: 0.01 mL/min
Beside the measured number, compound 3's estimate is 50-fold (1.70 log units) above it; the measured number lies below the stated range.
By their numbers in this assay, from the lowest: compound 3; then compound 1; then compound 2.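

In this assay, for the compounds shown here, the group on the sulfonyl sulfur matters far more than the first pair of compounds suggested: a 130-fold lower number from compound 2 to compound 3 (2.11 log units; beyond the scatter) comes with 3,4-difluorophenyl in place of 4-methoxyphenyl. Two halogen-bearing groups do not read alike either, for a 39-fold lower number from compound 1 to compound 3 (1.59 log units; beyond the scatter) accompanies only fluoro in place of chloro on an aromatic carbon. That single-atom change is larger than the change of the whole group, a 3.3-fold higher number from compound 1 to compound 2 (0.52 log units; beyond the scatter) on swapping 3-chloro-4-fluorophenyl for 4-methoxyphenyl. Nothing shown here gives a reason for these drops. Still open, as far as these compounds go, is whether the very low number depends on having both fluorines, as a phenyl ring with a single fluorine could show. From the compounds shown here alone, how a phenyl ring carrying a nitrile or an amine would read at this place is also open.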